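From trifluoromethyl to fluoro in an antiproliferative series

This account rests on a few compounds, and the source may have more. Where it says the series, first, only, none or still open, it means among the compounds named here.

Compound 1 (`COc1ccc(-c2noc(CCCCCCC(=O)NO)n2)cc1`) – 20400 nM
Compound 2 (`O=C(CCCCCCc1nc(-c2ccc(C(F)(F)F)cc2)no1)NO`) – 15300 nM

In a functional assay on NCI-H661 cells (Homo sapiens) for antiproliferative activity, read by MTT assay, with a stated time of 72 h (on this read-out higher numbers stand for weaker inhibition and lower numbers for stronger inhibition), compound 2 (15300 nM) stands level with compound 1 (20400 nM) within the scatter. Compound 3 (`O=C(CCCCCCc1nc(-c2ccc(F)cc2)no1)NO`) has fluoro in place of trifluoromethyl on an aromatic carbon. Within the data shown here, one measured step bears on this: trifluoromethyl in place of methoxy on an aromatic carbon, a change (a 1.3-fold lower number from compound 1 to compound 2 (0.12 log units; within the scatter)) that stayed within the scatter. No step beyond the scatter is therefore expected in this assay for the new change. The expected step is small (a 1.1-fold higher number from compound 2 to compound 3 (0.05 log units; within the scatter)). That expectation rests on a single step (a 1.3-fold lower number from compound 1 to compound 2 (0.12 log units; within the scatter)). Compound 3 is estimated at 17000 nM with an expected range (8500 nM to 34000 nM).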

Compound 3, half-maximal inhibitory concentration: 19400 nM
Compound 3: the middle estimate sits 1.1-fold (0.06 log units) below what was measured; low and high end bracket the measured number.
By their numbers in this assay, from the lowest: compounds 2, 3 and 1 (each within the scatter of the next).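

Swapping trifluoromethyl for the single fluorine on this aromatic carbon, para to a large group, leaves the number in this assay within the scatter (a 1.3-fold higher number from compound 2 to compound 3 (0.10 log units; within the scatter)). Fluoro in place of methoxy does the same (a 1.1-fold lower number from compound 1 to compound 3 (0.02 log units; within the scatter)), so all three groups now stand level at this place, and a much smaller group is tolerated as well as the two larger ones. Nothing at hand explains this flat response.

From the compounds shown here alone, whether an amine or a carboxylic acid on this carbon would stay level remains open. So does the effect of a longer chain ahead of the hydroxamic acid end.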